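A few compounds are considered here, and "the series" means these few. Any claim that something is new, unique, unknown or untested is made for them only; others in the source may bear on it.

Measured compounds:
- compound 1, `C=C1C(=O)[C@]23C[C@@]1(O)CC[C@H]2c1ccc(OS(=O)(=O)c2ccc(C)cc2)c(C)c1[C@@H]3Cn1cc(-c2ccccn2)nn1`, gives 320 nM in a functional assay on MCF7 cells (Homo sapiens) for cytotoxicity, read by MTT assay, with a stated time of 4 days; on this read-out lower numbers stand for stronger inhibition and higher numbers for weaker inhibition
- compound 2, `C=C1C(=O)[C@]23C[C@@]1(O)CC[C@H]2c1ccc(OS(=O)(=O)c2ccc(C)cc2)c(C)c1[C@@H]3Cn1cc(-c2ccc(Cl)cc2)nn1`, gives 1440 nM
- compound 3, `C=C1C(=O)[C@]23C[C@@]1(O)CC[C@H]2c1ccc(O)c(C)c1[C@@H]3Cn1cc(-c2ccc(Cl)cc2)nn1`, gives 2470 nM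

Among these three numbers compound 2 stands second highest. Its nearest neighbour is compound 3, and the step from compound 2 to compound 3 is a 1.7-fold higher number from compound 2 to compound 3 (0.23 log units; within the scatter), which replaces the (4-methylphenyl)sulfonyl on the ring oxygen with hydrogen. Its furthest neighbour is compound 1, and the step from compound 1 to compound 2 is a 4.5-fold higher number from compound 1 to compound 2 (0.65 log units; beyond the scatter), which swaps the ring attached to the triazole.

Compound 4, `C=C1C(=O)[C@]23C[C@@]1(O)CC[C@H]2c1ccc(OS(=O)(=O)c2ccc(C)cc2)c(C)c1[C@@H]3Cn1cc(-c2ccc(C)cc2)nn1`, differs from compound 2 by methyl in place of chloro on an aromatic carbon. Among the measured compounds shown here, of the two measured steps, only the one from compound 1 to compound 2 touches this same ring on the triazole, and it was modest. Compound 4 keeps the phenyl ring and changes only one small substituent, a smaller alteration than that swap, so the expected step in this assay from compound 2 to compound 4 is a 1.1-fold lower number from compound 2 to compound 4 (0.04 log units; within the scatter), likely not beyond the scatter in either direction. Compound 4 is therefore estimated at 1300 nM, with a range from 550 nM to 3100 nM.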

Compound 4, half-maximal inhibitory concentration: 320 nM
Compound 4: the middle estimate sits 4.1-fold (0.61 log units) above what was measured, and the stated range ends above it.
By their numbers in this assay, from the lowest: compounds 1 and 4 (each within the scatter of the next); then compounds 2 and 3 (each within the scatter of the next).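

In this assay, exchanging a single heavy atom on the phenyl ring, para to a large group, moves the number beyond the scatter: a 4.5-fold lower number from compound 2 to compound 4 (0.65 log units; beyond the scatter), with methyl in place of chloro. Before this, only the exchange of one whole ring for another had shown such a step, yet no change at the digits printed from compound 1 to compound 4 (within the scatter), so 4-methylphenyl and pyridin-2-yl cannot be told apart here, and the phenyl ring itself does not set the higher number of compound 2. No measurement shown explains why chloro and methyl differ.

Going by these compounds, how a methoxy group, an amine or plain hydrogen would compare at this place on the phenyl ring remains open. Also open, on these data alone, is whether methyl in place of chloro gives a similar step when the ring oxygen carries hydrogen instead of (4-methylphenyl)sulfonyl, as in compound 3.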